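Replacing 2-aminoethyl with phenyl on the shared core

The compounds below may be only part of what the source reports. "The series", "measured", "known", "first", "only" and "open" are said of these compounds alone.

For the measured compounds named here, only two compounds with this core have been measured so far. In a functional assay on SNB-19 cells (Homo sapiens) for antiproliferative activity, read by MTT assay (on this read-out higher numbers stand for weaker inhibition and lower numbers for stronger inhibition), compound 1 `CNC1=CC(=O)c2ccccc2C1=O` gives 114000 nM, and compound 2 `NCCCNC1=CC(=O)c2ccccc2C1=O` gives 71300 nM. Going by the values given here, the one measured step is a 1.6-fold lower number from compound 1 to compound 2 (0.20 log units; within the scatter), so the two numbers cannot be ranked and compound 2 stands with compound 1 at the same level.

Compound 3 `O=C1C=C(NCc2ccccc2)C(=O)c2ccccc21` has yet to be measured in this assay. It carries phenyl in place of 2-aminoethyl on a saturated chain carbon bound to an amine nitrogen.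

Among the compounds with values here, only one measured step bears on this change. It touches the same place, and replacing hydrogen there with 2-aminoethyl gave a 1.6-fold lower number from compound 1 to compound 2 (0.20 log units; within the scatter). Within the data shown here, that step stayed within the scatter, but no measured compound carries a ring at this place, so the data say little about phenyl and the uncertainty stays wide. No shift beyond the scatter is therefore expected, in either direction.

The expected change is a 1.4-fold lower number from compound 2 to compound 3 (0.15 log units; within the scatter). Compound 3 is estimated at 50000 nM, with an expected range from 15000 nM to 150000 nM.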

Compound 3, half-maximal inhibitory concentration: 80000 nM
The estimate for compound 3 lay 1.6-fold (0.20 log units) below the measured number; the measured number falls inside the stated range.
By their numbers in this assay, from the lowest: compounds 2, 3 and 1 (each within the scatter of the next).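

Phenyl is the first ring seen on a saturated chain carbon bound to an amine nitrogen, and in this assay the exchange for 2-aminoethyl gives a 1.1-fold higher number from compound 2 to compound 3 (0.05 log units; within the scatter) and so does not separate the two groups, although one has no ring and carries a hydrogen-bond donor and acceptor while the other is a six-membered aromatic ring with neither. Set against hydrogen, phenyl gives a 1.4-fold lower number from compound 1 to compound 3 (0.15 log units; within the scatter) as well, so hydrogen, 2-aminoethyl and phenyl at this place all stand at one level on this read-out, and a group of either kind shows no measurable effect here. Nothing shown offers an explanation for this flat picture.

Going by these compounds, whether any group at this place can move the number beyond the scatter stays open, and a carboxylic acid, a longer chain ending in an amine or a phenyl ring bearing a methoxy group would each test that in a different way. On these data alone, whether the other positions of the shared core respond any more strongly also remains open.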